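A few compounds are considered here, and "the series" means these few. Any claim that something is new, unique, unknown or untested is made for them only; others in the source may bear on it.

Measured compounds:

Compound 1 `O=C(NCCNS(=O)(=O)c1ccc(-c2ccccc2OCc2cccc(O)c2)s1)Nc1cc(Cl)cc(Cl)c1` — in a functional assay on HL-60 cells (Homo sapiens) for inhibition, read by CCK-8 assay, with a stated time of 48 h (on this read-out higher numbers stand for weaker inhibition and lower numbers for stronger inhibition), compound 1 gives 2800 nM.
Compound 2 `O=[N+]([O-])c1ccc(NC(=S)NCCNS(=O)(=O)c2ccc(-c3ccccc3OCc3cccc(O)c3)s2)cc1` — in this assay compound 2 gives 10800 nM.
Compound 3 `Cc1ccc(-c2ccsc2S(=O)(=O)NCCNC(=S)Nc2ccc([N+](=O)[O-])cc2)c(Oc2ccc(O)c(O)c2)c1` — in this assay compound 3 gives 2900 nM.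

Compound 1 and compound 2 share one core and differ in one place: a group of 11 heavy atoms (7 carbon, 1 nitrogen, 1 oxygen, 2 chlorine; one six-membered aromatic ring of carbon only) in place of a group of 12 heavy atoms (7 carbon, 2 nitrogen, 2 oxygen, 1 sulfur; one six-membered aromatic ring of carbon only), on an amine nitrogen. That change gives a 3.9-fold lower number from compound 2 to compound 1 (0.59 log units; beyond the scatter). Compound 3 sits on a second core; the difference between the two cores is not broken down here. In this assay compound 3 and compound 1 lie within the scatter of one another, while compound 2 stands apart from both.

Compound 4 `Cc1ccc(-c2ccsc2S(=O)(=O)NCCNC(=O)Nc2cc(Cl)cc(Cl)c2)c(Oc2ccc(O)c(O)c2)c1` is not yet measured. It is made from compound 3 by a group of 11 heavy atoms (7 carbon, 1 nitrogen, 1 oxygen, 2 chlorine; one six-membered aromatic ring of carbon only) in place of a group of 12 heavy atoms (7 carbon, 2 nitrogen, 2 oxygen, 1 sulfur; one six-membered aromatic ring of carbon only), on an amine nitrogen, the same change as from compound 2 to compound 1, at the same kind of place. Within the data shown here, the step from compound 3 to compound 4 in this assay is expected to be about a 3.6-fold lower number from compound 3 to compound 4 (0.56 log units; beyond the scatter), because the one earlier instance gave a 3.9-fold lower number from compound 2 to compound 1 (0.59 log units; beyond the scatter). Among the measured compounds shown here, compound 4 is therefore estimated at 800 nM, with a range of 300 nM to 2200 nM, the width reflecting that only one prior instance of this change exists.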

Compound 4, half-maximal inhibitory concentration: 3500 nM
Estimate against measurement, compound 4: 4.4-fold (0.64 log units) below; the whole stated range lies below it.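

On the core of compound 3, putting (3,5-dichlorophenyl)carbamoyl on the amine nitrogen in this assay gives a 1.2-fold higher number from compound 3 to compound 4 (0.08 log units; within the scatter). The change therefore does not carry over in size between these two cores: the same change on two cores in this assay, a 3.9-fold lower number (0.59 log units; beyond the scatter) from compound 2 to compound 1 and a 1.2-fold higher number (0.08 log units; within the scatter) from compound 3 to compound 4, 4.7-fold (0.67 log units) apart, beyond the scatter of two such steps

This shows that, for this pair of cores, a step measured on one core is a poor guide to the same step on the other, but with one instance per core it gives no rule for the series and does not show which feature of the cores is responsible. The change also replaces the sulfur-bearing link and the ring substituents in a single step, so the contribution of each part remains unresolved.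

The sulfur counterpart of (3,5-dichlorophenyl)carbamoyl, tested on both cores, could separate those two parts. As far as these compounds go, it also remains open how either core would respond to a carboxylic acid or an amine on that aromatic ring, or to a longer chain in the linker.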